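This account rests on a few compounds, and the source may have more. Where it says the series, first, only, none or still open, it means among the compounds named here.

Measured compounds and their values in a physicochemical assay for solubility, read by nephelometry, measured as kinetic solubility, at pH 2.0; a higher number here means a more soluble compound, a lower number a less soluble compound:

Compound 1, `NCc1csc(NC(=O)c2cc3ccccc3n2Cc2ccccc2)n1`, gives 25 ug/mL.
Compound 2, `COc1ccc(C(=O)Nc2nc(CN)cs2)cc1`, gives 50 ug/mL.
Compound 3, `CC(C)(C)c1cc(C(=O)Nc2ccncc2)n(Cc2ccccc2)n1`, gives > 100 ug/mL.

For compound 3 the value in this assay is a limit of the assay rather than a number, as shown by the limit of > 100 ug/mL in this assay, at which 1 of the 3 values shown sits. Compound 3 therefore stands at the top end of what the measurement can report, and its exact solubility is not known. Compound 1 and compound 2 sit below this limit, within the numbers the assay can read.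

The next compound, compound 4, `CC(C)(C)c1cc(C(=O)Nc2cccc(CN)c2)n(Cc2ccccc2)n1`, keeps the core of compound 3 and differs in a single place: 3-(aminomethyl)phenyl in place of pyridin-4-yl on an amide-type nitrogen. For the measured compounds named here, no pair of measured compounds differing in one place exists here, so the size of this step can only be expected, not read from the data. The expected step from compound 3 to compound 4 in this assay is a step that the limit leaves unreadable from compound 3 to compound 4, which is small or none beyond the scatter. Compound 4 is estimated to give 120 ug/mL in this assay, with a range from 50 ug/mL to 250 ug/mL.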

Compound 4, solubility: > 100 ug/mL
Compound 4 ended at the assay's limit; the forecaster's own chance of this, stated with the estimate: 65%; the middle value does not contradict the limit.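

For the compounds shown here, no step from compound 3 to compound 4 can be read in this assay, as both compounds end at a limit rather than a number: the limit of > 100 ug/mL in this assay, at which 2 of the 4 values shown sit.

Still open, from the compounds shown here alone, is whether 3-(aminomethyl)phenyl and pyridin-4-yl on the amide-type nitrogen give different solubility at all.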